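Carbamate aryl swap on the shared core

The source may hold more compounds than are shown below. What is called first, only, known or untested is meant among the compounds shown, and "the series" means these compounds.

Compound 3 `CC(C)=CCC/C(C)=C/CC1Cc2c(OC(=O)Nc3ccc(F)c(F)c3)cc(=O)n(CCCO)c2CC1(C)C` carries a (3,4-difluorophenyl)carbamoyl group on the ring oxygen of the shared core. In a functional assay on PANC-1 cells (Homo sapiens) for inhibition, read by MTT assay, with a stated time of 24 h, tested at 10 uM (on this read-out lower numbers stand for less inhibition and higher numbers for more inhibition at the one concentration tested (going by the name of the read-out)), compound 3 gives 4.8%. Compound 1 `CCOc1cc(=O)n(CCCO)c2c1CC(C/C=C(\C)CCC=C(C)C)C(C)(C)C2`, with ethyl in that place, gives 0.8%, and compound 2 `CC(C)=CCC/C(C)=C/CC1Cc2c(OCCCNC(=O)c3cccs3)cc(=O)n(CCCO)c2CC1(C)C`, with the chain bearing the (((thiophen-2-yl)carbonyl)amino)methyl group, gives 11.5%. Compound 3 thus sits among the other two numbers with no separation that counts: a number 4 percentage points higher from compound 1 to compound 3 (within the scatter) and a number 6.7 percentage points lower from compound 2 to compound 3 (within the scatter) are both within the scatter, and only a number 10.7 percentage points higher from compound 1 to compound 2 (beyond the scatter) is a modest step beyond it.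

Compound 4 `CC(C)=CCC/C(C)=C/CC1Cc2c(OC(=O)Nc3ccc(Cl)cc3)cc(=O)n(CCCO)c2CC1(C)C` differs from compound 3 by 4-chlorophenyl in place of 3,4-difluorophenyl on an amide-type nitrogen. Among the compounds with values here, no measured step touches the aryl on the amide-type nitrogen; the two steps involving the carbamate, to and from compound 3, were both within the scatter. With nothing in this set pointing in either direction, the step of a number 0.2 percentage points higher from compound 3 to compound 4 (within the scatter) is expected to stay within the scatter. Compound 4 is therefore estimated at 5%, with a range of 0% to 15% in this assay.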

Compound 4, a percentage reported as inhibition, at one concentration (the size of the read-out at that concentration, not a potency): 4.3%
Compound 4: middle estimate off by 0.7 percentage points, on the high side; the measured number falls inside the stated range.
By their numbers in this assay, from the lowest: compounds 1, 4, 3 and 2 (each within the scatter of the next, the first and the last beyond it).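

In this assay, within the data shown here, the first change on the amide-type nitrogen, 4-chlorophenyl in place of 3,4-difluorophenyl, cannot be told apart from no change (a number 0.5 percentage points lower from compound 3 to compound 4 (within the scatter)). The 4-chlorophenyl carbamate also stays within the scatter of both ethyl and the thiophene amide chain on the aromatic ring oxygen (a number 3.5 percentage points higher from compound 1 to compound 4 (within the scatter); a number 7.2 percentage points lower from compound 2 to compound 4 (within the scatter)), so the two aryl carbamates tested give the same picture at this position. Nothing at hand bears on this result.

Two halogenated phenyl groups leave open what a carboxylic acid or an amine on that phenyl ring would give. It also remains open whether a cyclohexyl group or a longer alkyl chain on the amide-type nitrogen would give a number beyond the scatter of these compounds.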